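From Pyrrolidine to Tetrahydroisoquinoline on a Shared Core

A few compounds are considered here, and "the series" means these few. Any claim that something is new, unique, unknown or untested is made for them only; others in the source may bear on it.

Of the compounds shown here, three have been measured in a functional assay on HCT-116 cells (Homo sapiens) for inhibition, read by MTT assay, with a stated time of 72 h, tested at 20 uM; on this read-out higher numbers stand for more inhibition at the one concentration tested (going by the name of the read-out) and lower numbers for less inhibition. Compound 1 `CNC(=O)c1cc(Oc2ccc(Nc3nccc(N4CCCC4)n3)cc2)ccn1` gives 66.4%, the top number of the three, yet compound 2 `CN(c1ccc(Oc2ncnc3ccsc23)cc1)c1nccc(N2CCCCC2)n1` gives 66.2%, which lies within the scatter of it, so these two cannot be ordered. Compound 3 `CN(c1ccc(Oc2ncnc3sccc23)cc1)c1nccc(N2CCCC2)n1` gives 42.2%, beyond the scatter below compound 1. Compound 4 `CNC(=O)c1cc(Oc2ccc(Nc3nccc(N4CCc5ccccc5C4)n3)cc2)ccn1` is not yet measured; it differs from compound 1 in one place: 1,2,3,4-tetrahydroisoquinolin-2-yl in place of pyrrolidin-1-yl on an aromatic carbon. For the measured compounds named here, no measured pair shows this change, so its effect is unknown. Because compound 1 stands at 66.4% and the entering group brings more heavy atoms and a second ring, a modest upward step is expected, near the scatter, in this assay. Compound 4 is expected to reach 72%, with a range of 52% to 90%. The estimated step is a number 5.6 percentage points higher from compound 1 to compound 4 (within the scatter).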

Compound 4, a percentage reported as inhibition, at one concentration (the size of the read-out at that concentration, not a potency): 31.2%
Compound 4: the middle estimate sits 40.8 percentage points above what was measured; measured number outside the range, below it.
By their numbers in this assay, from the lowest: compound 4; then compound 3; then compounds 2 and 1 (each within the scatter of the next).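

In this assay putting 1,2,3,4-tetrahydroisoquinolin-2-yl in place of pyrrolidin-1-yl on this aromatic carbon gives a number 35.2 percentage points lower from compound 1 to compound 4 (beyond the scatter) and so shows that the read-out depends on which ring amine sits at this position. Hydrogen-bond donors, acceptors and net charge stay the same across the change, while the heavy atoms and rings increase. Nothing available gives a cause for this drop. From the compounds shown here alone, it remains open whether the added aromatic ring or the larger non-aromatic ring goes with the loss. Going by these compounds, it also remains open how morpholin-4-yl or a dimethylamino group would read at this position.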